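The source may hold more compounds than are shown below. What is called first, only, known or untested is meant among the compounds shown, and "the series" means these compounds.

Compound 1 `COCC[C@H]1C[C@@H]1c1cncc(N2C[C@@H]3C[C@H]2CN3)c1` stands at the weak end of the two measured entries: in an assay on a protein complex for displacement of a labelled ligand from Neuronal acetylcholine receptor; alpha3/beta2 (Rattus norvegicus), read by scintillation counting (on this read-out higher numbers stand for weaker inhibition and lower numbers for stronger inhibition), compound 1 gives 141 nM, whereas compound 2 `c1cncc(N2CC3CC2CN3)c1` gives 3.1 nM, a gap well beyond the scatter. The two structures are not connected by a single change, so only their bare values are set side by side here. Compound 3 `COCC[C@@H]1C[C@H]1c1cncc(N2C[C@@H]3C[C@H]2CN3)c1` is the next entry, still to be measured in this assay. Against compound 1 it differs only in drawn configuration: the two compounds have the same atoms and bonds and differ only in configuration as drawn: 2 of 4 stereo elements differ; a stereocentre at a saturated ring carbon is drawn R in compound 1 and S in compound 3; a stereocentre at a saturated ring carbon is drawn S in compound 1 and R in compound 3. The remaining two stereo elements are unchanged. Among the measured compounds shown here, no measured pair reports such an inversion at two saturated ring carbons, so its effect cannot be read from the data. The expectation is for a modest shift in this assay, with compound 1 already holding the highest number, and the direction is open. Compound 3 is estimated at 80 nM, with a range of 20 nM to 400 nM. That estimate amounts to an expected step of a 1.8-fold lower number from compound 1 to compound 3 (0.25 log units; within the scatter).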

Compound 3, inhibition constant: 617 nM
Beside the measured number, compound 3's estimate is 7.7-fold (0.89 log units) below it, outside the stated range (above it).
By their numbers in this assay, from the lowest: compound 2; then compound 1; then compound 3.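

In this assay, among the compounds shown here, the inversion of the two saturated ring carbons gives a 4.4-fold higher number from compound 1 to compound 3 (0.64 log units; beyond the scatter) and is the first reading of configuration. The step can be assigned to configuration alone because nothing else separates the pair: the fact that compounds 1 and 3 differ only in the configuration as drawn. For the compounds shown here, of the two arrangements tested, the one drawn in compound 1 gives the lower number, so with atoms and bonds held fixed, the configuration at these two carbons moves the read-out beyond the scatter.

The compounds shown leave open how much each of the two inverted carbons contributes on its own. Going by these compounds, it also remains open whether the preference for the arrangement in compound 1 would hold with an amine, a carboxylic acid or a longer chain in place of the side chain of compound 1.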